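Removing the Acetyl: an Expected Cytotoxicity for Compound 4

The source may report more compounds than this note shows. Statements on the series, on what has been measured and on what is new or still open speak of the compounds shown alone.

Four compounds built on two closely related cores are compared in an ADME assay on MT4 cells (Homo sapiens) for cytotoxicity, read by MTT assay, with a stated time of 4 days; on this read-out higher numbers stand for lower toxicity in this test and lower numbers for higher toxicity in this test. Compound 1 `COc1cccc(-c2cc(=O)c3cc(NC(C)=O)ccc3o2)c1` carries an acetyl on a nitrogen on an aromatic ring. In this assay compound 1 gives only a limit, > 404000 nM. Compound 2 `COc1ccc(-c2cc(=O)c3cc(NC(C)=O)ccc3o2)cc1` has the same atoms as compound 1 joined differently; the difference between the two cores is not broken down here. In this assay compound 2 gives 226000 nM. Compound 3 `COc1cccc(-c2cc(=O)c3cc(N)ccc3o2)c1` is compound 1 with hydrogen in place of acetyl on a nitrogen on an aromatic ring, and in this assay compound 3 gives 247000 nM. The measured step is an at least 1.6-fold lower number from compound 1 to compound 3 (0.21 log units; that floor lies within the scatter); its size is known only as a floor because the limit of > 404000 nM in this assay, at which 1 of the 3 values shown sits, is all that compound 1 gives.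

Compound 4 `COc1ccc(-c2cc(=O)c3cc(N)ccc3o2)cc1` has not been measured in this assay. It is compound 2 with hydrogen in place of acetyl on a nitrogen on an aromatic ring, the same change as that from compound 1 to compound 3, made at the same place. The expected step from compound 2 to compound 4 rests on the measured step from compound 1 to compound 3 and on the value of compound 2 in this assay, 226000 nM. Compound 4 is therefore expected to give about 150000 nM in this assay. That number would mean an estimated 1.5-fold lower number from compound 2 to compound 4 (0.18 log units; within the scatter). The range expected for compound 4 runs from 60000 nM to 400000 nM, with the lower end marking greater toxicity in this test.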

Compound 4, half-maximal cytotoxic concentration: 241000 nM
Estimate against measurement, compound 4: 1.6-fold (0.21 log units) below, and the stated range covers the measured number.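

In this assay, hydrogen in place of acetyl on a nitrogen on an aromatic ring gives a 1.1-fold higher number from compound 2 to compound 4 (0.03 log units; within the scatter), so on this core the change produces no step beyond the usual scatter. Set beside the same change on the other core, this reading offers no sign of a clear difference, but it cannot rule one out: the same change on two cores in this assay, an at least 1.6-fold lower number (0.21 log units; that floor lies within the scatter) from compound 1 to compound 3 and a 1.1-fold higher number (0.03 log units; within the scatter) from compound 2 to compound 4; the limit leaves it open whether they differ. The step on the core of compound 1 is known only as a floor, so the series does not show whether the change keeps the same size from one core to the other, and a firm number for compound 1 would be needed to settle that: the limit of > 404000 nM in this assay, at which 1 of the 4 values shown sits.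

The compounds shown leave open how this assay would read with other groups on that nitrogen, such as a longer acyl chain, a methyl group or a methanesulfonyl group, compared with acetyl and hydrogen. They also leave open whether the same change would read alike on cores that carry a hydroxyl group or a fluorine atom where these compounds carry the methoxy group.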